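Removing the Methyl from the Phenyl Ether of Compound 1

The source may report more compounds than this note shows. Statements on the series, on what has been measured and on what is new or still open speak of the compounds shown alone.

Compound 1 `COc1ccc(-c2cc3c(OC)cc(OC)cc3n(C)c2=O)cc1` is measured in a functional assay on T47D cells (Homo sapiens) for cytotoxicity, read by colorimetric assay and MTT assay (a lower number here means a stronger inhibitor, a higher number a weaker inhibitor), where compound 1 gives 10000 nM. Compound 2 `COc1ccc(-c2cc3c(OC)cc(OC)cc3n(CCC(=O)OCc3ccccc3)c2=O)cc1` carries (benzyloxycarbonyl)methyl in place of hydrogen on a saturated chain carbon bound to an aromatic nitrogen, and in this assay compound 2 gives 10000 nM. The step of no change at the digits printed from compound 1 to compound 2 (within the scatter) lies within the scatter. On the numbers shown, compound 1 therefore stands level with compound 2. Compound 3 `COc1cc(OC)c2cc(-c3ccc(O)cc3)c(=O)n(C)c2c1` differs from compound 1 at another place: hydrogen in place of methyl on an oxygen on an aromatic ring. Among the measured compounds shown here, no measured step touches this oxygen; the only known step concerns the chain on the aromatic nitrogen and gives no guide for a change from 4-methoxyphenyl to 4-hydroxyphenyl. With nothing pointing in either direction, the step of no change at the digits printed from compound 1 to compound 3 (within the scatter) is expected to stay within the scatter. Compound 3 is accordingly estimated at 10000 nM in this assay, with a range from 3000 nM to 30000 nM.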

Compound 3, half-maximal inhibitory concentration: 10000 nM
Estimate against measurement, compound 3: no gap at the digits printed; the range from low to high includes it.
By their numbers in this assay, from the lowest: compounds 1, 2 and 3 (each within the scatter of the next).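

In this assay, hydrogen in place of methyl on an oxygen on an aromatic ring gives no change at the digits printed from compound 1 to compound 3 (within the scatter), so this oxygen now has a measured step of its own, which the earlier step on the chain at the aromatic nitrogen could not supply. Compound 1 now has single changes at two separate places, the other being no change at the digits printed from compound 1 to compound 2 (within the scatter), and neither moves the value at the digits printed. No evidence bears on this result.

What the compounds shown leave open is whether a different group on this ring, such as an amine, a carboxylic acid or a longer alkoxy chain, would shift the value in this assay. On these data alone, it also remains open whether 4-hydroxyphenyl would read the same alongside the (benzyloxycarbonyl)methyl chain of compound 2.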